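Chloro for Methoxy: Expected Tolerance of Compound 4

The compounds below may be only part of what the source reports. "The series", "measured", "known", "first", "only" and "open" are said of these compounds alone.

Measured so far in this assay:
compound 1, `CNC(=S)N/N=C1\C(=O)Nc2ccccc21`: > 25000 nM
compound 2, `COc1cccc(NC(=S)N/N=C2\C(=O)Nc3ccccc32)c1`: > 25000 nM
compound 3, `CCCN(CCC)C(=S)N/N=C1/C(=O)Nc2ccccc21`: > 25000 nM

Of the compounds shown here, three have been tested in an ADME assay on RD cells (Homo sapiens) for cytotoxicity; a lower number here means that less compound is tolerated, a higher number that more compound is tolerated. For compound 1 the result > 25000 nM is a limit of the assay rather than a number. Compound 2 likewise reaches only the limit > 25000 nM. Compound 3 also stops at the limit > 25000 nM. Compound 2 therefore stands at the same place as the other two, namely (the limit of > 25000 nM in this assay, at which 3 of the 3 values shown sit), and nothing separates the three from one another.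

Compound 4 `O=C1Nc2ccccc2/C1=N/NC(=S)Nc1cccc(Cl)c1` differs from compound 2 by chloro in place of methoxy on an aromatic carbon. Within the data shown here, no pair of measured compounds shows what this change does here. Among the measured compounds shown here, since every value so far sits at the limit of > 25000 nM in this assay, at which 3 of the 3 values shown sit, the step from compound 2 to compound 4 is expected to be none beyond the scatter, a step that the limit leaves unreadable from compound 2 to compound 4. Compound 4 is expected to give about 30000 nM, with a range from 15000 nM to 100000 nM, most probably reported once more as a limit.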

Compound 4, half-maximal cytotoxic concentration: > 25000 nM
Compound 4: a limit, no number (the forecaster's own chance of this, stated with the estimate: 85%); the middle value is on the limit's open side.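

In this assay compound 4 gives > 25000 nM, again a limit and not a number, so the steps to compound 4 from compound 2 and from compound 1 cannot be read. The compounds shown leave open at what concentration any of them becomes toxic to the cells, and whether chloro and methoxy differ at all here: the limit of > 25000 nM in this assay, at which 4 of the 4 values shown sit.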